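Removing or adding a methyl on the ring amine

This account rests on a few compounds, and the source may have more. Where it says the series, first, only, none or still open, it means among the compounds named here.

Of the compounds shown here, three sharing one bridged core have been tested in an in vitro functional assay on SH-SY5Y cells for agonist activity at Neuronal acetylcholine receptor; alpha3/beta4 (Homo sapiens), read by FLIPR and calcium flux; on this read-out lower numbers stand for an effect already at smaller amounts and higher numbers for an effect only at larger amounts of compound. Compound 1 `CN1C[C@H]2C=C(c3cccnc3)C[C@H](C2)C1`, which carries a methyl on its ring amine, gives 7530 nM. Compound 2 `C1=C(c2cccnc2)C[C@H]2CNC[C@@H]1C2`, the same skeleton with hydrogen on that nitrogen, gives 37 nM, and the change is a 200-fold lower number from compound 1 to compound 2 (2.31 log units; beyond the scatter). Compound 3 `C1=C(c2cccnc2)C[C@@H]2CNC[C@H]1C2` is the mirror image of the preceding compound, and compound 3 gives 73 nM; the step is a 2.0-fold higher number from compound 2 to compound 3 (0.30 log units; within the scatter), so the two mirror images cannot be told apart on this read-out, a point that rests on (the fact that compounds 2 and 3 differ only in the configuration as drawn). Among the three numbers compound 3 sits close to compound 2 and far from compound 1.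

Compound 4 `CN1C[C@@H]2C=C(c3cccnc3)C[C@@H](C2)C1` is not yet measured. It differs from compound 3 by methyl in place of hydrogen on an amine nitrogen in a ring. Among the measured compounds shown here, this is the reverse of the only substituent change seen so far, the one from compound 1 to compound 2, which was large and went toward lower numbers. Putting the methyl back is therefore expected to push the number strongly upward in this assay, by about a 190-fold higher number from compound 3 to compound 4 (2.28 log units; beyond the scatter). Compound 4 is thus estimated at 14000 nM, with a likely range from 4000 nM to 45000 nM.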

Compound 4, half-maximal effective concentration: > 10000 nM
Compound 4: only a limit was reported (the forecaster's own chance of this, stated with the estimate: 20%); the middle value lies beyond the limit too.
By their numbers in this assay, from the lowest: compounds 2 and 3 (each within the scatter of the next); then compound 1. At a limit, above all of these: compound 4.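

Putting a methyl on the amine nitrogen in the ring gives an at least 130-fold higher number from compound 3 to compound 4 (2.13 log units; beyond the scatter), so in this assay the large loss seen with one mirror image of the shared core also appears with the other: the same change on two cores in this assay, a 200-fold lower number (2.31 log units; beyond the scatter) from compound 1 to compound 2 and an at least 130-fold lower number (2.13 log units; beyond the scatter) from compound 4 to compound 3; the limit leaves it open whether they differ. For compound 4, the reported > 10000 nM is a limit and not a number. The two methyl compounds cannot be put in order, as the comparison gives only an at least 1.3-fold higher number from compound 1 to compound 4 (0.12 log units; that floor lies within the scatter), and they differ only in their drawn configuration: the fact that compounds 1 and 4 differ only in the configuration as drawn.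

As far as these compounds go, how far compound 4 really lies beyond its limit stays open, and with it the question of whether the methyl costs exactly the same in both mirror-image forms. The compounds shown also leave open how the read-out would respond to other groups on this ring nitrogen, such as an ethyl, a longer chain or an acetyl, since only hydrogen and methyl appear there.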